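Taking one chloro off compound 3

The compounds below may be only part of what the source reports. "The series", "measured", "known", "first", "only" and "open" are said of these compounds alone.

For the measured compounds named here, in a functional assay on BEAS-2B cells (Homo sapiens) for inhibition, read by MTT assay, with a stated time of 72 h (on this read-out higher numbers stand for weaker inhibition and lower numbers for stronger inhibition), compound 3 (`C=C(c1ccc(Cl)c(Cl)c1Cl)C1COC2(CCCCC2)OO1`) gives 10300 nM and stands lowest of the three numbers so far, with steps to both others beyond the scatter. Compound 1 (`C=C(c1ccc(Cl)c(Cl)c1)C1COC2(CCCCC2)OO1`) gives 39400 nM in the same read-out. Compound 2 (`C=C(c1ccc(F)c(F)c1)C1COC2(CCCC2)OO1`) gives 73600 nM but differs from compound 3 in more than one place, so it offers no clean comparison.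

Compound 4 (`C=C(c1ccc(Cl)cc1Cl)C1COC2(CCCCC2)OO1`) is not yet measured and carries hydrogen in place of chloro on an aromatic carbon relative to compound 3. Going by the values given here, the only measured step that bears on this is the gain of a chloro at another aromatic carbon, a 3.8-fold lower number from compound 1 to compound 3 (0.58 log units; beyond the scatter) (modest, beyond the scatter). Read in reverse, that step points to a higher number in this assay on losing a chloro, although the carbon involved is not the same, so the size carries over only loosely. The expected change is a 2.7-fold higher number from compound 3 to compound 4 (0.43 log units; beyond the scatter) (a modest rise). The estimate for compound 4 is 28000 nM (12000 nM to 65000 nM).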

Compound 4, half-maximal inhibitory concentration: 16700 nM
The estimate for compound 4 lay 1.7-fold (0.22 log units) above the measured number, and the stated range covers the measured number.
By their numbers in this assay, from the lowest: compounds 3 and 4 (each within the scatter of the next); then compounds 1 and 2 (each within the scatter of the next).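

In this assay, the chloro ortho to two chloro groups and meta to a large group can give way to hydrogen with a shift that stays within the scatter, a 1.6-fold higher number from compound 3 to compound 4 (0.21 log units; within the scatter) in this case. The other listed chloro step, a 3.8-fold lower number from compound 1 to compound 3 (0.58 log units; beyond the scatter) on a different aromatic carbon, lies beyond the scatter, so among these compounds the result of a chloro change depends on the carbon that carries it. Nothing at hand bears on the reason for this difference.

Still open, as far as these compounds go, is whether a fluoro, a methoxy or an amine on this same aromatic carbon would leave the number within the scatter of the hydrogen and chloro compounds. Also open, from the compounds shown here alone, is whether the same replacement gives a similar result on the core of compound 2.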